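A second chloro on a compound at the limit

A few compounds are considered here, and "the series" means these few. Any claim that something is new, unique, unknown or untested is made for them only; others in the source may bear on it.

Values so far in a functional assay on HL-60 cells (Homo sapiens) for antiproliferative activity, read by MTT assay, with a stated time of 72 h (on this read-out lower numbers stand for stronger inhibition and higher numbers for weaker inhibition), are these, each of them a limit of the assay and not a number:

- Compound 1 `COc1cc(-n2ncnc2-c2ccc(Cl)cc2)cc(OC)c1OC` gives > 10000 nM as a limit
- Compound 2 `COc1cc(-c2ncnn2-c2ccc([N+](=O)[O-])cc2)cc(OC)c1OC` gives > 10000 nM as a limit
- Compound 3 `COc1cc(-n2ncnc2-c2ccc(OC(F)(F)F)cc2)cc(OC)c1OC` gives > 10000 nM as a limit

Compound 1 therefore has no measured number to start from, and the same holds for the other two compounds, as the limit of > 10000 nM in this assay, at which 3 of the 3 values shown sit, shows. Compound 4 `COc1cc(-n2ncnc2-c2ccc(Cl)c(Cl)c2)cc(OC)c1OC` keeps the core of compound 1 and has chloro in place of hydrogen on an aromatic carbon, ortho to a chloro group and meta to a large group chloro in place of hydrogen on an aromatic carbon so that 4-chlorophenyl becomes 3,4-dichlorophenyl. Among the compounds with values here, the only measured step that bears on this change is a step that the two limits leave unreadable from compound 1 to compound 3 and it offers neither a size nor a direction. No step beyond the scatter can therefore be forecast in this assay and the result is expected to stay close to that same limit. The expected step is a number no higher from compound 1 to compound 4 (the limit leaves the size open) with no direction to claim. Compound 4 is expected at 10000 nM within an estimated range from 3000 nM to 30000 nM in that read-out.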

Compound 4, half-maximal inhibitory concentration: > 10000 nM
Compound 4 was reported as a limit (the forecaster's own chance of this, stated with the estimate: 85%); the middle value lies on the limit itself.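

Within the data shown here, compound 1 and compound 4 both give only limits in this assay, so no step between them can be read: the limit of > 10000 nM in this assay, at which 4 of the 4 values shown sit. The compounds shown leave open whether chloro in place of hydrogen changes the activity at all, and which change would bring a value off that limit.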